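From an amine to a sulfanyl group in compound 4

A few compounds are considered here, and "the series" means these few. Any claim that something is new, unique, unknown or untested is made for them only; others in the source may bear on it.

- compound 1 `OC[C@H]1O[C@@H](n2cnc3c(CSCc4ccccc4)ncnc32)[C@H](O)[C@@H]1O`: > 100000 nM (a limit)
- compound 2 `CN(Cc1ccccc1)Cc1ncnc2c1ncn2[C@@H]1O[C@H](CO)[C@@H](O)[C@H]1O`: 9000 nM
- compound 3 `CC(C)N(Cc1ncnc2c1ncn2[C@@H]1O[C@H](CO)[C@@H](O)[C@H]1O)C(C)C`: 18000 nM

In a functional assay on Huh-7 cells (Homo sapiens) for cytotoxicity, read by MTT assay, with a stated time of 3 days (a lower number here means that less compound is tolerated, a higher number that more compound is tolerated), compound 3 gives 18000 nM and cannot be told apart from the other amine (a 2.0-fold higher number from compound 2 to compound 3 (0.30 log units; within the scatter)). Compound 1 gives > 100000 nM in this assay, which is a limit and not a number.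

Compound 4 `OC[C@H]1O[C@@H](n2cnc3c(CSc4ccccc4)ncnc32)[C@H](O)[C@@H]1O` carries phenylsulfanyl in place of diisopropylamino on a saturated chain carbon bound to an aromatic carbon. Going by the values given here, two measured steps bear on this, and both lie beyond the scatter: (an at least 5.5-fold lower number from compound 1 to compound 3 (0.74 log units; beyond the scatter)) and (an at least 11-fold lower number from compound 1 to compound 2 (1.04 log units; beyond the scatter)). Both lead away from the benzylsulfanyl group of compound 1. Compound 4 returns to a sulfanyl group, so a step the opposite way, to a higher number of moderate size, is expected (a 3.3-fold higher number from compound 3 to compound 4 (0.52 log units; beyond the scatter)). Compound 4 is estimated at 60000 nM (range 20000 nM to 100000 nM).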

Compound 4, half-maximal cytotoxic concentration: > 100000 nM
Compound 4: a limit, no number; the forecaster's own chance of this, stated with the estimate: 45%; middle value at least 1.6-fold (0.22 log units) from the limit.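

A second sulfanyl group now stands apart from both amines at this position on the saturated chain carbon, so the gap seen with compound 1 does not depend on the benzyl group (an at least 5.5-fold higher number from compound 3 to compound 4 (0.74 log units; beyond the scatter); an at least 11-fold higher number from compound 2 to compound 4 (1.04 log units; beyond the scatter)). In this assay, the change from benzyl to phenyl on the sulfur cannot be read, because compound 1 and compound 4 share one limit: the limit of > 100000 nM in this assay, at which 2 of the 4 values shown sit.

On these data alone, whether the sulfur or the attached ring sets the difference stays open. A methylsulfanyl group and a phenylamino group would separate these two parts.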